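Amine swap on the cyclooctyl amide: lipophilicity notes

The source may hold more compounds than are shown below. What is called first, only, known or untested is meant among the compounds shown, and "the series" means these compounds.

Compound 2 `CC(C)=CCC/C(C)=C/CC/C(C)=C/CSC[C@H](NC(=O)CCCCCN1CCCC1)C(=O)NC1CCCCCCC1` stands highest of the two numbers in hand in a physicochemical assay for lipophilicity (on this read-out higher numbers stand for higher lipophilicity and lower numbers for lower lipophilicity), where compound 2 gives 5.37. For the measured compounds named here, compound 1 `CC(C)=CCC/C(C)=C/CC/C(C)=C/CSC[C@H](NC(=O)CCCCCN1CCN(C)CC1)C(=O)NC1CCCC1` gives 4.55 in this assay, a gap beyond the scatter; no single step links these two, so only the two values are noted. Compound 3 `CC(C)=CCC/C(C)=C/CC/C(C)=C/CSC[C@H](NC(=O)CCCCCN1CCN(C)CC1)C(=O)NC1CCCCCCC1` is not yet measured. Its change from compound 2: 4-methylpiperazin-1-yl in place of pyrrolidin-1-yl on a saturated chain carbon, five bonds along the chain from a carbonyl carbon. A step downward beyond the scatter is expected, a number 0.67 log units lower from compound 2 to compound 3 (beyond the scatter). Compound 3 is therefore estimated at 4.7 in this assay, within 4.2 to 5.2.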

Compound 3, distribution coefficient: 5.88
Beside the measured number, compound 3's estimate is 1.18 log units below it; the measured number lies above the stated range.
By their numbers in this assay, from the lowest: compound 1; then compound 2; then compound 3.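

In this assay, 4-methylpiperazin-1-yl in place of pyrrolidin-1-yl on a saturated chain carbon, five bonds along the chain from a carbonyl carbon, gives a number 0.51 log units higher from compound 2 to compound 3 (beyond the scatter) on the cyclooctyl amide. With 4-methylpiperazin-1-yl held fixed, cyclooctyl in place of cyclopentyl on an amide-type nitrogen gives a number 1.33 log units higher from compound 1 to compound 3 (beyond the scatter) and is the larger of the two steps. Nothing at hand accounts for either step.

Going by these compounds, whether the amine swap moves the number the same way on the cyclopentyl amide stays open. So does where a morpholine or piperidine at this place would fall relative to compound 2 and compound 3.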